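Ethoxy on the anilide ring: working notes

The compounds below may be only part of what the source reports. "The series", "measured", "known", "first", "only" and "open" are said of these compounds alone.

- compound 1 `COc1cc2c(cc1OC)C(=O)C(C(=O)Nc1ccccc1)C2`: 61.3 ug/mL
- compound 2 `CCc1ccc(NC(=O)C2Cc3cc(OC)c(OC)cc3C2=O)cc1`: 76.2 ug/mL
- compound 3 `CCc1cccc(NC(=O)C2Cc3cc(OC)c(OC)cc3C2=O)c1`: 64.1 ug/mL

In a physicochemical assay, with a stated time of 30 min (a higher number here means a weaker inhibitor, a lower number a stronger inhibitor), compound 1 gives 61.3 ug/mL, which lies within the scatter of compound 2 and compound 3, so the three cannot be ranked.

Next is compound 4 `CCOc1ccccc1NC(=O)C1Cc2cc(OC)c(OC)cc2C1=O`, which has ethoxy in place of hydrogen on an aromatic carbon.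

The closest evidence comes from ethyl in place of hydrogen on an aromatic carbon, which gave a 1.2-fold higher number from compound 1 to compound 2 (0.09 log units; within the scatter) and a 1.0-fold higher number from compound 1 to compound 3 (0.02 log units; within the scatter). Exchanging 4-ethylphenyl for 3-ethylphenyl gave a 1.2-fold lower number from compound 2 to compound 3 (0.08 log units; within the scatter). Among the compounds with values here, all of these steps are small, but no measured compound carries ethoxy, so they are only indirect guidance and the range is kept wide.

No step beyond the scatter is expected in this assay, and no direction is favoured: the estimated step is a 1.1-fold higher number from compound 1 to compound 4 (0.05 log units; within the scatter).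

For compound 4 the expected value is 68 ug/mL, with an estimated range of 45 ug/mL to 100 ug/mL.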

Compound 4, half-maximal inhibitory concentration: 63.7 ug/mL
For compound 4 the middle estimate is 1.1-fold (0.03 log units) above the measured one; measured number inside the range.
By their numbers in this assay, from the lowest: compounds 1, 4, 3 and 2 (each within the scatter of the next).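

Ethoxy on an aromatic carbon, ortho to a large group, leaves this assay essentially unmoved, with a 1.0-fold higher number from compound 1 to compound 4 (0.02 log units; within the scatter) and compound 4 at 63.7 ug/mL. Within the data shown here, the earlier compounds carried only ethyl on the anilide ring, so this is the first sign that an oxygen-linked chain at this position also stays within the scatter of the unsubstituted anilide. Nothing available explains why the change makes so little difference.

Going by these compounds, whether this flat response holds for every kind of group at this position remains open: an amine or a carboxylic acid here could still give a step beyond the scatter. A longer chain, such as butoxy, could show whether this position stays as undemanding once the group grows beyond ethoxy.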